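This account rests on a few compounds, and the source may have more. Where it says the series, first, only, none or still open, it means among the compounds named here.

Measured compounds:
Compound 1, `Cc1cc(C)cc(S(=O)(=O)c2c(C(=O)N[C@@H]3CCN(Cc4cccnc4)C3)[nH]c3ccc(Cl)cc23)c1`, gives 36500 nM in an ADME assay on MT4 cells (Homo sapiens) for cytotoxicity, read by MTT assay, with a stated time of 5 days; a higher number here means that more compound is tolerated, a lower number that less compound is tolerated.
Compound 3, `Cc1cc(C)cc(S(=O)(=O)c2c(C(=O)NC3CN(Cc4cccnc4)C3)[nH]c3ccc(Cl)cc23)c1`, gives 36000 nM in this assay.
Compound 2, `Cc1cc(C)cc(S(=O)(=O)c2c(C(=O)N[C@@H]3CCN(Cc4ccccc4C#N)C3)[nH]c3ccc(Cl)cc23)c1`, gives >= 186000 nM in this assay; this is a limit of the assay, not a number.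

From compound 1 to compound 2 the change is 2-cyanophenyl in place of pyridin-3-yl on a saturated chain carbon bound to an amine nitrogen in a ring, and it brought an at least 5.0-fold higher number from compound 1 to compound 2 (0.70 log units; beyond the scatter), a step that ends at the limit of >= 186000 nM in this assay, at which 1 of the 3 values shown sits. Compound 1 and compound 3 differ in their cores by 1-((pyridin-3-yl)methyl)azetidin-3-yl in place of 1-((pyridin-3-yl)methyl)pyrrolidin-3-yl on an amide-type nitrogen, a swap that gave a 1.0-fold lower number from compound 1 to compound 3 (0.01 log units; within the scatter). Compound 4, `Cc1cc(C)cc(S(=O)(=O)c2c(C(=O)NC3CN(Cc4ccccc4C#N)C3)[nH]c3ccc(Cl)cc23)c1`, is not yet measured; it carries the same change as before, (2-cyanophenyl in place of pyridin-3-yl on a saturated chain carbon bound to an amine nitrogen in a ring), on the core of compound 3. Since compound 3 gives 36000 nM, much like compound 1, the expected step is a 5.0-fold higher number from compound 3 to compound 4 (0.70 log units; beyond the scatter). Compound 4 is estimated at 180000 nM, between 90000 nM and 400000 nM.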

Compound 4, half-maximal cytotoxic concentration: > 234000 nM
Compound 4 gave a limit, no number (the forecaster's own chance of this, stated with the estimate: 60%); middle value at least 1.3-fold (0.11 log units) away from the limit.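

In this assay, 2-cyanophenyl in place of pyridin-3-yl on a second core gave an at least 6.5-fold higher number from compound 3 to compound 4 (0.81 log units; beyond the scatter), so the higher number seen on the first core appears here too. Compound 4 gives > 234000 nM, which is a limit of the assay and not a number. The two steps point the same way, but their true sizes remain unknown, since each ends at a limit: the same change on two cores in this assay, an at least 5.0-fold higher number (0.70 log units; beyond the scatter) from compound 1 to compound 2 and an at least 6.5-fold higher number (0.81 log units; beyond the scatter) from compound 3 to compound 4; the limit leaves it open whether they differ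

Only two cores are shown, so it remains open whether the change would carry to a third core. Also open, on these data alone, is whether an amine or a carboxylic acid in place of the nitrile would raise the number in this assay as well.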